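Amide nitrogen variation in a biphenyl acetate series

This account rests on a few compounds, and the source may have more. Where it says the series, first, only, none or still open, it means among the compounds named here.

Measured in a functional assay on the whole organism (Ear) for inhibition, with Mus musculus as the target, at a dose of 40 mg/kg by the oral route; a lower number here means less inhibition, a higher number more inhibition at the dose given (going by the name of the read-out):
- compound 1 `CNC(=O)c1cc(-c2ccc(F)cc2F)ccc1OC(C)=O`: 48.8%
- compound 2 `CC(=O)Oc1ccc(-c2ccc(F)cc2F)cc1C(=O)NC1CCCCC1`: 0%
- compound 3 `CC(=O)Oc1ccc(-c2ccc(F)cc2F)cc1C(=O)Nc1ccccc1Cl`: 41.4%

Compound 2 gives the lowest of the three numbers in this assay, with compound 3 the nearest and compound 1 the furthest. The two steps touching compound 2 are both large: a number 48.8 percentage points lower from compound 1 to compound 2 (beyond the scatter) and a number 41.4 percentage points higher from compound 2 to compound 3 (beyond the scatter). The remaining step between the two other compounds is small: a number 7.4 percentage points lower from compound 1 to compound 3 (within the scatter). So far, then, the amide substituent decides everything seen in this assay, and the cyclohexyl compound is the one that falls out.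

Compound 4 `CC(=O)Oc1ccc(-c2ccc(F)cc2F)cc1C(=O)NN1CCOCC1` has not been measured in this assay. The change from compound 2 is morpholin-4-yl in place of cyclohexyl on an amide-type nitrogen. For the measured compounds named here, no measured step swaps a carbocycle for a saturated ring with hetero atoms, so the two steps away from compound 2 bear on this only in the sense that every change at this position so far has moved the number far upward from compound 2. The morpholin-4-yl compound is expected to rise from the floor of compound 2 as well, though less certainly than the aryl or methyl amides did. The estimated step is a number 20 percentage points higher from compound 2 to compound 4 (beyond the scatter). Compound 4 is therefore expected at about 20% in this assay, with a range from 0% to 50%.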

Compound 4, a percentage reported as inhibition, in the whole organism at one dose (the size of the read-out at that dose, not a potency): 0%
For compound 4 the middle estimate is 20 percentage points above the measured one; low and high end bracket the measured number.
By their numbers in this assay, from the lowest: compounds 2 and 4 (each within the scatter of the next); then compounds 3 and 1 (each within the scatter of the next).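

In this assay, replacing the carbon-only ring with one holding 2 hetero atoms gives no change at the digits printed from compound 2 to compound 4 (within the scatter), so the 2 hydrogen-bond acceptors counted for morpholin-4-yl do not separate this compound from the cyclohexyl amide. The new ring also reproduces the large gaps to the other two amides, with a number 41.4 percentage points lower from compound 3 to compound 4 (beyond the scatter) and a number 48.8 percentage points lower from compound 1 to compound 4 (beyond the scatter), so across these four compounds the two six-membered non-aromatic rings on the amide-type nitrogen stand apart from methyl and 2-chlorophenyl, and no compound shown goes against this split. Nothing available accounts for the split.

Open, going by these compounds, is where the drop sets in between methyl and the six-membered rings: an ethyl, an isopropyl or a cyclopropyl group on the same nitrogen would each test this. Also open, on these data alone, is whether the aryl result depends on the chlorine, which an unsubstituted phenyl would show, and whether a piperidin-1-yl group would match morpholin-4-yl on this nitrogen.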